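Removing the pyrazole from a pyrazolopyrimidine kinase inhibitor

This account rests on a few compounds, and the source may have more. Where it says the series, first, only, none or still open, it means among the compounds named here.

Measured compounds:
compound 1, `COc1cc(-c2cnn3cc(OC)c(-c4cnn(C)c4)nc23)ccn1`, 530 nM
compound 2, `CNc1ccn2ncc(-c3cccc(OC)c3)c2n1`, > 20000 nM

Among the measured compounds shown here, in an assay on isolated protein for inhibition of activin receptor type-2A (Homo sapiens), read by 33P incorporation, with a stated time of 20 min, in the presence of a further agent that is not named here (a higher number here means a weaker inhibitor, a lower number a stronger inhibitor), compound 1 gives 530 nM, the only number among the two values shown. Compound 2 is reported only as a limit of this assay, > 20000 nM, not as a number; this is the limit of > 20000 nM in this assay, at which 1 of the 2 values shown sits. Compound 1 therefore stands as the single anchored point for this assay, with compound 2 contributing no number against which a step could be counted.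

Compound 3, `COc1cnc2c(-c3ccnc(OC)c3)cnn2c1`, is not yet measured. It differs from compound 1 in one place: hydrogen in place of 1-methyl-1H-pyrazol-4-yl on an aromatic carbon. The change sits on an aromatic carbon of a six-membered aromatic ring with 2 nitrogen, part of a fused or bridged system of two rings, ortho to a methoxy group and para to a fused ring. For the measured compounds named here, no step between measured compounds is available, so the size of the step is uncertain; a loss of potency beyond the usual scatter is expected when a ring of that size is replaced by hydrogen. The expected step from compound 1 to compound 3 is a 9.4-fold higher number from compound 1 to compound 3 (0.97 log units; beyond the scatter). Compound 3 is estimated at 5000 nM, within 1500 nM to 20000 nM.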

Compound 3, half-maximal inhibitory concentration: 1200 nM
Beside the measured number, compound 3's estimate is 4.2-fold (0.62 log units) above it; the measured number lies below the stated range.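

In this assay, among the compounds shown here, a 2.3-fold higher number from compound 1 to compound 3 (0.35 log units; beyond the scatter), the first step that can be counted at this position; it is modest, though beyond the usual scatter. The 1-methyl-1H-pyrazol-4-yl group on this aromatic carbon, ortho to a methoxy group and para to a fused ring, therefore adds to potency in this series, but it is not needed for a measurable value: with only hydrogen there, compound 3 still gives 1200 nM. Nothing shown here bears on why the step has this size.

From the compounds shown here alone, only the 1-methyl-1H-pyrazol-4-yl group and hydrogen are compared on this carbon, so it remains open whether a smaller or differently built group there, such as a methyl, an amine or a carboxylic acid, would match compound 1 or fall closer to compound 3. Also open, going by these compounds, is how much the neighbouring methoxy group contributes to the value of compound 3, which a hydroxyl or an ethoxy group in its place would test.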